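The compounds below may be only part of what the source reports. "The series", "measured", "known", "first", "only" and "open" are said of these compounds alone.

Among the measured compounds shown here, in a functional assay on BCG823 cells (Homo sapiens) for antiproliferative activity, read by MTT assay, with a stated time of 48 h (a lower number here means a stronger inhibitor, a higher number a weaker inhibitor), compound 1 `O=c1cc(-c2ccccc2)oc2cc(OCc3ccccc3)c(OCCCCN3CCCCC3)c(O)c12` gives 3000 nM, the lower of the two numbers so far, and compound 2 `COc1cc2oc(-c3ccccc3)cc(=O)c2c(O)c1OCCCCN1CCCCC1` gives 21900 nM. For the measured compounds named here, the only measured step, a 7.3-fold higher number from compound 1 to compound 2 (0.86 log units; beyond the scatter), is modest but beyond the scatter. It is hydrogen in place of phenyl on a saturated chain carbon bound to an oxygen on an aromatic ring. Compound 3 `CN(C)CCCOc1c(OCc2ccccc2)cc2oc(-c3ccccc3)cc(=O)c2c1O` keeps that phenyl and differs at the amine end: dimethylamino in place of (piperidin-1-yl)methyl on a saturated chain carbon, three bonds along the chain from an oxygen on an aromatic ring. In words, this is dimethylamino in place of (piperidin-1-yl)methyl, and cut further out it reads 4-(piperidin-1-yl)butyl to 3-(dimethylamino)propyl. Going by the values given here, no measured step covers this change, so the one step available serves only as a loose guide to size, and the direction is tentative. A modest move to a higher number in this assay is expected, as a 2.0-fold higher number from compound 1 to compound 3 (0.30 log units; within the scatter). The estimated value for compound 3 is 6000 nM, with an expected range of 1800 nM to 20000 nM.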

Compound 3, half-maximal inhibitory concentration: 5500 nM
Compound 3: the middle estimate sits 1.1-fold (0.04 log units) above what was measured, and the stated range covers the measured number.
By their numbers in this assay, from the lowest: compounds 1 and 3 (each within the scatter of the next); then compound 2.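

In this assay the amine end of the chain gives no separable difference: dimethylamino in place of (piperidin-1-yl)methyl, a 1.8-fold higher number from compound 1 to compound 3 (0.26 log units; within the scatter), stays within the scatter, unlike the earlier step of hydrogen in place of phenyl. Among the compounds shown here, the swap from 4-(piperidin-1-yl)butyl to 3-(dimethylamino)propyl changes the chain and the amine together, so this pair shows only that the combined change leaves the number within the scatter, and neither part can be read alone. Nothing measured on these compounds explains this result.

Still open, as far as these compounds go, is how each part acts alone, which 3-(piperidin-1-yl)propyl or 4-(dimethylamino)butyl on the same core would separate. Also open, from the compounds shown here alone, is whether another amine at the chain end, such as morpholine or pyrrolidine, or a longer chain, would move the number beyond the scatter.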